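Piperazine substituent change in the phthalazinone series: compound 4

The compounds below may be only part of what the source reports. "The series", "measured", "known", "first", "only" and "open" are said of these compounds alone.

Measured so far:
compound 1, `Cc1ccc(-c2nn(CCCCN3CCN(c4ccccc4)CC3)c(=O)c3ccccc23)cc1`, 23.9 nM
compound 2, `CCOc1ccccc1N1CCN(CCCCn2nc(-c3ccc(C)cc3)c3ccccc3c2=O)CC1`, 2.23 nM
compound 3, `Cc1ccc(-c2nn(CCCCN3CCN(CC4COc5ccccc5O4)CC3)c(=O)c3ccccc23)cc1`, 180 nM

In an assay on Cerebral cortex for displacement of a labelled ligand from Adrenergic receptor alpha-1 (Rattus norvegicus) (on this read-out higher numbers stand for weaker inhibition and lower numbers for stronger inhibition), compound 3 gives the highest number of the three, set apart from compound 1 and compound 2 by gaps beyond the scatter. The next compound, compound 4, `Cc1ccc(-c2nn(CCCCN3CCN(c4cccc(C(F)(F)F)c4)CC3)c(=O)c3ccccc23)cc1`, carries 3-(trifluoromethyl)phenyl in place of (2,3-dihydro-1,4-benzodioxin-2-yl)methyl on an amine nitrogen in a ring. Within the data shown here, two measured steps bear on this change, both running the opposite way: a 7.5-fold higher number from compound 1 to compound 3 (0.88 log units; beyond the scatter) and an 81-fold higher number from compound 2 to compound 3 (1.91 log units; beyond the scatter). Putting an aromatic ring back directly on the ring nitrogen, as in compound 1 and compound 2, is therefore expected to lower the number in this assay by a large margin. Among the measured compounds shown here, there is no measured compound with a trifluoromethyl on that aryl ring, so how far compound 4 departs from compound 1 cannot be read from the data. Compound 4 is estimated at 30 nM in this assay, within 8 nM to 120 nM, meaning an expected step of a 6.0-fold lower number from compound 3 to compound 4 (0.78 log units; beyond the scatter).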

Compound 4, inhibition constant: 112 nM
Estimate against measurement, compound 4: 3.7-fold (0.57 log units) below; low and high end bracket the measured number.
By their numbers in this assay, from the lowest: compound 2; then compound 1; then compounds 4 and 3 (each within the scatter of the next).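

In this assay, an aromatic ring directly on the amine nitrogen does not by itself set a compound apart from the (2,3-dihydro-1,4-benzodioxin-2-yl)methyl analogue, as the step is a 1.6-fold lower number from compound 3 to compound 4 (0.21 log units; within the scatter). What the aromatic ring carries matters at this position: trifluoromethyl in place of hydrogen gives a 4.7-fold higher number from compound 1 to compound 4 (0.67 log units; beyond the scatter), whereas 3-(trifluoromethyl)phenyl in place of 2-ethoxyphenyl gives a 50-fold higher number from compound 2 to compound 4 (1.70 log units; beyond the scatter), so ethoxy and trifluoromethyl move the number in opposite directions relative to the unsubstituted phenyl of compound 1. Nothing on hand explains these steps.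
As far as these compounds go, whether this contrast follows the group itself or its place on the aromatic ring remains open. Also open, from the compounds shown here alone, is where a methoxy group or a chlorine on that ring would fall in this order.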